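The compounds below may be only part of what the source reports. "The series", "measured", "known", "first", "only" and "open" are said of these compounds alone.

Values in a functional assay on HepG2 cells (Homo sapiens) for antiproliferative activity, read by MTT assay, with a stated time of 48 h; on this read-out higher numbers stand for weaker inhibition and lower numbers for stronger inhibition:

- compound 1, `Cc1ccc(-c2nc3ccc(Cl)cc3c(=O)[nH]2)cc1`: 9.86 ug/mL
- compound 2, `Cc1ccc(-c2nc3ccc(Cl)cc3c(=S)[nH]2)cc1`: 7.01 ug/mL
- compound 3, `Cc1ccc(-c2nc3ccc(Cl)cc3c(=O)n2N)cc1`: 18.4 ug/mL

Compound 3 is made from compound 1 by one change, (amino in place of hydrogen on an aromatic nitrogen), and in this assay this gave a 1.9-fold higher number from compound 1 to compound 3 (0.27 log units; within the scatter). Compound 1 and compound 2 share most of their structure, but the difference between the two cores is not broken down here; in this assay compound 2 and compound 1 lie within the usual scatter of each other, while compound 3 gives a higher number than compound 2.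

Compound 4, `Cc1ccc(-c2nc3ccc(Cl)cc3c(=S)n2N)cc1`, is not yet measured. Going by the values given here, it is made from compound 2 by amino in place of hydrogen on an aromatic nitrogen, the same change as the one from compound 1 to compound 3, at a place described in the same words. On that single precedent, the step from compound 2 to compound 4 in this assay is expected to be about a 1.9-fold higher number from compound 2 to compound 4 (0.27 log units; within the scatter), of a size close to a 1.9-fold higher number from compound 1 to compound 3 (0.27 log units; within the scatter), though one pair is a thin basis. Compound 4 is therefore estimated to give 13 ug/mL in this assay, with a range from 6 ug/mL to 28 ug/mL.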

Compound 4, half-maximal inhibitory concentration: 17 ug/mL
Compound 4: middle estimate off by 1.3-fold (0.12 log units), on the low side; the range from low to high includes it.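

In this assay, amino in place of hydrogen on an aromatic nitrogen gives a 2.4-fold higher number from compound 2 to compound 4 (0.38 log units; beyond the scatter), a modest rise in the number and so a modest loss of inhibition. Set beside the earlier step, the change carries across the two cores with a similar size and the same direction: the same change on two cores in this assay, a 1.9-fold higher number (0.27 log units; within the scatter) from compound 1 to compound 3 and a 2.4-fold higher number (0.38 log units; beyond the scatter) from compound 2 to compound 4, 1.3-fold (0.11 log units) apart, within the scatter of two such steps. Going by these compounds alone, this rests on only two pairs, one step within the scatter and one beyond it, so it supports transfer between the core of compound 1 and the core of compound 2 but sets no rule for other cores and gives no reason for the loss.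

Open, as far as these compounds go, is whether a methyl group, a hydroxyl group or a longer chain on that ring nitrogen would behave as amino does, or whether a substituted amine would. Also open, from the compounds shown here alone, is whether the amino step holds on cores carrying fluorine or methoxy in place of the chlorine.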